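A Halogen Swap on the Benzoyl Arm of Compound 2

The source may report more compounds than this note shows. Statements on the series, on what has been measured and on what is new or still open speak of the compounds shown alone.

Among the measured compounds shown here, compound 2 `CC(C)OC(=O)C1=CN(C(=O)c2ccc(F)cc2)CC(C)(C)c2cc(C#N)[nH]c21` holds the lowest of the two numbers measured so far. In an assay on HEK293 cells for agonist activity at Bile acid receptor (Homo sapiens), read by a luciferase reporter (a higher number here means that more compound is needed for the effect, a lower number that less compound is needed), compound 2 gives 5 nM. For the measured compounds named here, the only other measured compound, compound 1 `CC(C)OC(=O)C1CN(C(=O)c2ccc(C#N)cc2)CC(C)(C)c2cc(C#N)[nH]c21`, differs from it in more than one place; in this assay compound 1 gives 5700 nM. The gap between the two lies well beyond the usual scatter, so compound 2 stands clearly below compound 1, and nothing more can be read from that pair alone.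

Compound 3 `CC(C)OC(=O)C1=CN(C(=O)c2cccc(Cl)c2)CC(C)(C)c2cc(C#N)[nH]c21` has not yet been measured. It differs from compound 2 in a single place: 3-chlorophenyl in place of 4-fluorophenyl on a carbonyl carbon. Going by the values given here, no pair of measured compounds isolates an exchange of this kind, so there is no measured step to lean on. The author therefore expects the number for compound 3 to remain close to that of compound 2, and in this assay the expected step is a 1.6-fold higher number from compound 2 to compound 3 (0.20 log units; within the scatter), a shift not clearly beyond the scatter. For compound 3 the estimate in this assay is 8 nM, with a range from 2 nM to 40 nM.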

Compound 3, half-maximal effective concentration: 12 nM
Beside the measured number, compound 3's estimate is 1.5-fold (0.18 log units) below it; low and high end bracket the measured number.
By their numbers in this assay, from the lowest: compound 2; then compound 3; then compound 1.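

Among the compounds shown here, the exchange of 4-fluorophenyl for 3-chlorophenyl on a carbonyl carbon gives, in this assay, a 2.4-fold higher number from compound 2 to compound 3 (0.38 log units; beyond the scatter), the first change confined to one place. The step is modest but beyond the scatter, which shows that the number responds to the aryl group on this carbonyl carbon, even when the heavy-atom count of the group and its counted donors and acceptors stay the same. It also shows that a 3-chlorophenyl group can stand here while compound 3 keeps a value of 12 nM. No accompanying measurement bears on what lies behind this step.

The step joins two changes, the identity of the halogen and its place on the phenyl ring, and a 4-chlorophenyl or a 3-fluorophenyl group on the same carbonyl carbon would be needed to tell them apart. Also open, from the compounds shown here alone, is how the number would respond to a phenyl group without a halogen or to one carrying an amine or a methoxy group, so the reach of this position remains undefined.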